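Benzyloxy Dichloro Swap on a Urea Analogue

This account rests on a few compounds, and the source may have more. Where it says the series, first, only, none or still open, it means among the compounds named here.

Compound 1 `Cc1ccc(NC(=S)NC(=O)c2ccc(OCc3ccccc3Cl)cc2)cc1-c1nc2ccccc2[nH]1` gives 51400 nM in a functional assay on MNK45 cells (Homo sapiens) for inhibition, read by MTT assay, with a stated time of 48 h; a higher number here means a weaker inhibitor, a lower number a stronger inhibitor. Compound 2 `Cc1ccc(NC(=S)NC(=O)c2ccc(OCc3ccc(Cl)c(Cl)c3)cc2)cc1-c1nc2ccccc2[nH]1` gives 8410 nM in this assay, and the change between them, (3,4-dichlorophenyl in place of 2-chlorophenyl on a saturated chain carbon bound to an oxygen on an aromatic ring), made a 6.1-fold lower number from compound 1 to compound 2 (0.79 log units; beyond the scatter). Compound 3 `Cc1ccc(NC(=O)NC(=O)c2ccc(OCc3ccccc3Cl)cc2)cc1-c1nc2ccccc2[nH]1` gives 21500 nM in this assay; the difference between its core and the core of compound 1 is not broken down here. Compound 4 `Cc1ccc(NC(=O)NC(=O)c2ccc(OCc3ccc(Cl)c(Cl)c3)cc2)cc1-c1nc2ccccc2[nH]1` has not yet been measured in this assay. It differs from compound 3 by 3,4-dichlorophenyl in place of 2-chlorophenyl on a saturated chain carbon bound to an oxygen on an aromatic ring, the same change that was made from compound 1 to compound 2, at the same place. Because the earlier step was a 6.1-fold lower number from compound 1 to compound 2 (0.79 log units; beyond the scatter), a step of a similar but perhaps somewhat smaller size is expected, namely a 4.3-fold lower number from compound 3 to compound 4 (0.63 log units; beyond the scatter). Compound 4 is therefore estimated to give 5000 nM in this assay, with the likely range running from 2000 nM to 15000 nM.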

Compound 4, half-maximal inhibitory concentration: 5820 nM
Beside the measured number, compound 4's estimate is 1.2-fold (0.07 log units) below it; the range from low to high includes it.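

In this assay, 3,4-dichlorophenyl in place of 2-chlorophenyl again lowers the number, giving a 3.7-fold lower number from compound 3 to compound 4 (0.57 log units; beyond the scatter). Set beside the earlier step, the two sizes cannot be told apart: the same change on two cores in this assay, a 6.1-fold lower number (0.79 log units; beyond the scatter) from compound 1 to compound 2 and a 3.7-fold lower number (0.57 log units; beyond the scatter) from compound 3 to compound 4, 1.7-fold (0.22 log units) apart, within the scatter of two such steps. Among the compounds shown here, the change therefore carries over from the core of compound 1 to the core of compound 3 at a comparable size, but this rests on only two cores and shows neither why the step has this size nor whether it would hold on any other core.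

The compounds shown leave open how the step would run with a trifluoromethylphenyl or a pyridine ring in place of 3,4-dichlorophenyl. They also leave open what a longer chain would do at the same place.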